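The source may report more compounds than this note shows. Statements on the series, on what has been measured and on what is new or still open speak of the compounds shown alone.

Compound 1, with structure `Cc1ccc(C(c2c[nH]c3ccccc23)c2c[nH]c3ccccc23)cc1`, was tested in an ADME assay on WS1 cells (Homo sapiens) for cytotoxicity, read by MTT assay, with a stated time of 48 h (on this read-out higher numbers stand for weaker inhibition and lower numbers for stronger inhibition), where compound 1 gives 58400000 nM. Compound 2, with structure `Fc1cc(F)cc(C(c2c[nH]c3ccccc23)c2c[nH]c3ccccc23)c1`, differs from it by 3,5-difluorophenyl in place of 4-methylphenyl on a saturated chain carbon bound to two aromatic carbons, and in this assay compound 2 gives 36000000 nM. That single change produced a step of a 1.6-fold lower number from compound 1 to compound 2 (0.21 log units; within the scatter).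

Compound 3, with structure `COc1ccc2[nH]cc(C(c3ccc(C)cc3)c3c[nH]c4ccc(OC)cc34)c2c1`, stands on a different core; how the core of compound 3 differs from the core of compound 1 is not broken down here. In this assay compound 3 gives 38600000 nM, a value lying close to that of compound 2.

Compound 4, with structure `COc1ccc2[nH]cc(C(c3cc(F)cc(F)c3)c3c[nH]c4ccc(OC)cc34)c2c1`, has not yet been measured. It differs from compound 3 by 3,5-difluorophenyl in place of 4-methylphenyl on a saturated chain carbon bound to two aromatic carbons, which is the same change already seen from compound 1 to compound 2, at the same place on the molecule. For compound 4 the expected step is a 1.5-fold lower number from compound 3 to compound 4 (0.17 log units; within the scatter), resting on the measured step of a 1.6-fold lower number from compound 1 to compound 2 (0.21 log units; within the scatter), which was small. Compound 4 is therefore estimated at 26000000 nM, with a likely range from 10000000 nM to 65000000 nM.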

Compound 4, half-maximal inhibitory concentration: 26500000 nM
The estimate for compound 4 lay 1.0-fold (0.01 log units) below the measured number; measured number inside the range.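

Replacing 4-methylphenyl with 3,5-difluorophenyl on the core of compound 3 gave a 1.5-fold lower number from compound 3 to compound 4 (0.16 log units; within the scatter) in this assay, a step that can be read directly against the earlier one. The two steps agree: the same change on two cores in this assay, a 1.6-fold lower number (0.21 log units; within the scatter) from compound 1 to compound 2 and a 1.5-fold lower number (0.16 log units; within the scatter) from compound 3 to compound 4, 1.1-fold (0.05 log units) apart, within the scatter of two such steps. This shows that on these two cores the change carries over with a step of similar size, and that on neither core does the step rise beyond the scatter; it does not show that the change has a real effect on the number, and two cores cannot speak for the whole series or show that a larger step would carry over in the same way.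

The compounds shown leave open whether other groups in this place, such as an amine, a carboxylic acid or a longer chain, would give a step beyond the scatter. They also leave open whether the same match would hold on a core carrying a chlorine or a hydroxyl group.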